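A few compounds are considered here, and "the series" means these few. Any claim that something is new, unique, unknown or untested is made for them only; others in the source may bear on it.

Compound 1 `CCCNC(=O)Nc1cc2nc(C3CCCCC3)[nH]c2cc1N(CC)CC` is one of two members of this series with a measured result. In an ADME assay on Vero cells (Chlorocebus sabaeus) for cytotoxicity, read by resazurin assay, with a stated time of 3 days (on this read-out higher numbers stand for weaker inhibition and lower numbers for stronger inhibition), compound 1 gives > 100 ug/mL, which is a limit of the assay rather than a number. Compound 2 `CN(C)c1cc2[nH]c(C3CCCCC3)nc2cc1NC(=O)c1ccc(F)cc1` belongs to the same set. In this assay compound 2 likewise gives > 100 ug/mL, again a limit. Among the compounds with values here, compound 1 thus stands where the only other measured compound also stands, at the limit of > 100 ug/mL in this assay, at which 2 of the 2 values shown sit.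

Compound 3 `C=Cc1cccc(C(=O)Nc2cc3nc(C4CCCCC4)[nH]c3cc2N(CC)CC)c1` has not yet been measured. It differs from compound 1 at the carbonyl carbon: 3-vinylphenyl in place of propylamino on a carbonyl carbon. Within the data shown here, with no measured step to lean on and both known values sitting at the limit, no step beyond the usual scatter is expected here in either direction. The expected step of a number no higher from compound 1 to compound 3 (the limit leaves the size open) is therefore none beyond the scatter. Compound 3 is expected to give about 100 ug/mL in this assay, within a range from 25 ug/mL to 300 ug/mL, most probably reported once more as a limit rather than a number.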

Compound 3, half-maximal inhibitory concentration: > 100 ug/mL
Compound 3: a limit, no number; the forecaster's own chance of this, stated with the estimate: 70%; the middle value lies on the limit itself.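

No step can be read between compound 1 and compound 3, because both results are limits and not numbers: the limit of > 100 ug/mL in this assay, at which 3 of the 3 values shown sit. The compounds shown leave open what actual value any of them has, and whether 3-vinylphenyl in place of propylamino on a carbonyl carbon changes cytotoxicity at all.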